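A few compounds are considered here, and "the series" means these few. Any claim that something is new, unique, unknown or untested is made for them only; others in the source may bear on it.

Three compounds sharing an amine-linked triazolothiadiazine core with a pendant aryl ring have been measured in a functional assay on HCT-116 cells (Homo sapiens) for inhibition, read by sulforhodamine B assay, with a stated time of 72 h; on this read-out higher numbers stand for weaker inhibition and lower numbers for stronger inhibition. Compound 1, `COc1ccc2cc(C(C)c3nnc4n3N=C(c3ccc([N+](=O)[O-])cc3)CS4)ccc2c1`, gives 15100 nM. Compound 2, `COc1ccc2cc(C(C)c3nnc4n3N=C(c3ccc(Br)cc3)CS4)ccc2c1`, gives 11700 nM. Compound 3, `CC(C)Cc1ccc(C(C)c2nnc3n2N=C(c2ccc(Br)cc2)CS3)cc1`, gives 7100 nM; the difference between the core of compound 3 and the core of compound 2 is not broken down here.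

Compound 4, `CC(C)Cc1ccc(C(C)c2nnc3n2N=C(c2ccc([N+](=O)[O-])cc2)CS3)cc1`, is not yet measured. It relates to compound 3 by nitro in place of bromo on an aromatic carbon. The same change, (nitro in place of bromo on an aromatic carbon), is already seen once among the measured compounds, where it made a 1.3-fold higher number from compound 2 to compound 1 (0.11 log units; within the scatter).

Because the step of a 1.3-fold higher number from compound 2 to compound 1 (0.11 log units; within the scatter) lies within the scatter, compound 4 is expected to sit close to compound 3, and the expected step is a 1.3-fold higher number from compound 3 to compound 4 (0.10 log units; within the scatter). The estimate for compound 4 in this assay is accordingly 9000 nM, with a plausible span from 4500 nM to 18000 nM; it rests on a single earlier instance of the change, so the span is kept wide.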

Compound 4, half-maximal inhibitory concentration: "not active" (no number reported)
Compound 4 has no reported number here, and the estimate cannot be compared.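

For the compounds shown here, compound 4 is reported as not active in this assay with no number given, so no step from compound 3 to compound 4 can be read. Nothing shown here bears on this result. The compounds shown leave open how the change from 4-bromophenyl to 4-nitrophenyl acts on the core of compound 3.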